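A few compounds are considered here, and "the series" means these few. Any claim that something is new, unique, unknown or untested is made for them only; others in the source may bear on it.

Compounds measured so far:
- compound 1 `COc1ccc(CSc2nnc(-c3cc(OC)c(OC)c(OC)c3)n2-c2ccc(OC)cc2)cc1`: 49600 nM
- compound 2 `COc1ccc(C(=O)CSc2nnc(-c3cc(OC)c(OC)c(OC)c3)n2-c2ccc(OC)cc2)cc1`: > 60000 nM
- compound 3 `COc1ccc(-n2c(SCC(=O)c3ccc(F)cc3)nnc2-c2cc(OC)c(OC)c(OC)c2)cc1`: > 60000 nM

All three were read in a functional assay on HCT-116 cells (Homo sapiens) for inhibition, read by MTT assay, with a stated time of 48 h; on this read-out higher numbers stand for weaker inhibition and lower numbers for stronger inhibition. For compound 3 the entry > 60000 nM is a limit and not a number. For compound 2 the entry > 60000 nM is also a limit. Compound 3 can therefore be placed only by the limit of > 60000 nM in this assay, at which 2 of the 3 values shown sit.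

Compound 4 `COc1ccc(NC(=O)CSc2nnc(-c3cc(OC)c(OC)c(OC)c3)n2-c2ccc(OC)cc2)cc1` carries (4-methoxyphenyl)amino in place of 4-fluorophenyl on a carbonyl carbon, so that (4-fluorophenyl)carbonyl becomes (4-methoxyphenyl)carbamoyl: (4-methoxyphenyl)amino in place of 4-fluorophenyl on a carbonyl carbon.

Going by the values given here, no measured step makes this change. The nearest steps are an at least 1.2-fold higher number from compound 1 to compound 2 (0.08 log units; that floor lies within the scatter) and an at least 1.2-fold higher number from compound 1 to compound 3 (0.08 log units; that floor lies within the scatter), and neither floor goes beyond the scatter. The aryl change gives only a step that the two limits leave unreadable from compound 2 to compound 3. Among the compounds with values here, the sole number is compound 1 at 49600 nM, and the expectation for compound 4 rests on that value. A modest move to a lower number is expected in this assay, though a further limit would be no surprise. The expected step is an at least 1.5-fold lower number from compound 3 to compound 4 (0.17 log units; that floor lies within the scatter). For compound 4 the estimated value is 40000 nM, with an expected range of 12000 nM to 60000 nM.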

Compound 4, half-maximal inhibitory concentration: > 60000 nM
Compound 4 was reported as a limit; the forecaster's own chance of this, stated with the estimate: 45%; middle value at least 1.5-fold (0.17 log units) away from the limit.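

Compound 4 in this assay is a limit and not a number, so (4-methoxyphenyl)amino on the carbonyl carbon, which brings the amide hydrogen, gives no more of a reading than the 4-fluorophenyl of compound 3 or the 4-methoxyphenyl of compound 2. Going by these compounds alone, the steps from compound 2 and from compound 3 to compound 4 cannot be read, since both ends of each are limits, and the one readable step, an at least 1.2-fold higher number from compound 1 to compound 4 (0.08 log units; that floor lies within the scatter), does not separate compound 4 from compound 1. With three different groups on this carbonyl carbon now ending alike, the carbamoyl change adds no usable contrast to the series, which stays pressed against one ceiling: the limit of > 60000 nM in this assay, at which 3 of the 4 values shown sit.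

From the compounds shown here alone, what remains open is whether any group on this carbonyl carbon can bring the series back to a readable number, for instance a carboxylic acid, a piperazine amide or an aliphatic amine in place of (4-methoxyphenyl)amino. Also open, going by these compounds, is whether a longer chain between the sulfur and the carbonyl, or a change on the shared core, would give a value that can be ranked against compound 1 at 49600 nM.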